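Extending a para-methyl group on a shared indole core

The source may hold more compounds than are shown below. What is called first, only, known or untested is meant among the compounds shown, and "the series" means these compounds.

Compound 1 `CCCCc1ccc2[nH]c(-c3ccc(OC)cc3)c(C=O)c2c1` gives 6.7 nM in a functional assay on MDA-MB-231 cells (Homo sapiens) for antiproliferative activity, with a stated time of 4 days; a higher number here means a weaker inhibitor, a lower number a stronger inhibitor. Compound 2 `CCCCCc1ccc2[nH]c(-c3ccc(OC)cc3)c(C=O)c2c1` gives 5.5 nM, a step of a 1.2-fold lower number from compound 1 to compound 2 (0.09 log units; within the scatter) for the change (methyl in place of hydrogen on a saturated chain carbon, four bonds along the chain from an aromatic carbon). Compound 3 `CCCCc1ccc2[nH]c(-c3ccc(C)cc3)c(C=O)c2c1` gives 34 nM; here the change methyl in place of methoxy on an aromatic carbon made a step of a 5.1-fold higher number from compound 1 to compound 3 (0.71 log units; beyond the scatter). Compound 4 `CCCCc1ccc2[nH]c(-c3ccc(CC)cc3)c(C=O)c2c1` is not yet measured. The change from compound 3 to compound 4 is methyl in place of hydrogen on a saturated chain carbon bound to an aromatic carbon, the same kind of change as from compound 1 to compound 2, but the place differs: there the carbon was four bonds along the chain from an aromatic carbon, here it is bound to an aromatic carbon. Because that earlier step was a 1.2-fold lower number from compound 1 to compound 2 (0.09 log units; within the scatter), a step of about a 1.4-fold lower number from compound 3 to compound 4 (0.13 log units; within the scatter) is expected for compound 4. Compound 4 is therefore estimated at 25 nM, between 10 nM and 60 nM.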

Compound 4, half-maximal inhibitory concentration: 27 nM
Beside the measured number, compound 4's estimate is 1.1-fold (0.03 log units) below it, and the stated range covers the measured number.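

Extending methyl to ethyl gives a 1.3-fold lower number from compound 3 to compound 4 (0.10 log units; within the scatter), and in this assay the same change behaves alike on the two cores: the same change on two cores in this assay, a 1.2-fold lower number (0.09 log units; within the scatter) from compound 1 to compound 2 and a 1.3-fold lower number (0.10 log units; within the scatter) from compound 3 to compound 4, 1.0-fold (0.01 log units) apart, within the scatter of two such steps This shows agreement between only two pairs, both with steps within the scatter, so it sets no rule for other cores or for places on the molecule not tested here. Ethyl also stays clearly apart from methoxy, with a 4.0-fold higher number from compound 1 to compound 4 (0.61 log units; beyond the scatter), so this extension does not close that gap.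

The compounds shown leave open whether a longer chain such as propyl, or an amine, in place of the ethyl would come closer to methoxy. They also leave open whether a hydroxyl group there would do so.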